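Exchanging the Aryl Group on a Saturated Ring Carbon

The compounds below may be only part of what the source reports. "The series", "measured", "known", "first", "only" and "open" are said of these compounds alone.

Of the compounds shown here, three have been tested in a functional assay on Ehrlich cells (Mus musculus) for cytotoxicity, tested at 10 ug/mL; a higher number here means a stronger effect of the compound at the concentration tested, a lower number a weaker effect. Compound 1 `COc1cc(N2C(N)=C(C#N)C(c3c(OC)ccc4ccccc34)C3=C2CC(C)(C)CC3=O)cc(OC)c1OC` gives 0%. Compound 2 `COc1ccccc1C1C(C#N)=C(N)N(c2cc(OC)c(OC)c(OC)c2)C2=C1C(=O)CC(C)(C)C2` gives 30%. Compound 3 `COc1cc(N2C(N)=C(C#N)C(c3ccc(C)o3)C3=C2CC(C)(C)CC3=O)cc(OC)c1OC` gives 21%.

Among these three numbers compound 2 shows the largest, but the gap to compound 3 is small: a number 9 percentage points lower from compound 2 to compound 3 (within the scatter), so the two cannot be told apart. The gap to compound 1 is real: a number 30 percentage points higher from compound 1 to compound 2 (beyond the scatter).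

Compound 4 `COc1cc(N2C(N)=C(C#N)C(c3ccc(O)cc3)C3=C2CC(C)(C)CC3=O)cc(OC)c1OC` has not yet been measured. It differs from compound 2 in one place: 4-hydroxyphenyl in place of 2-methoxyphenyl on a saturated ring carbon. Within the data shown here, the steps that bear on this are those that exchanged the group on the same saturated ring carbon: a number 30 percentage points higher from compound 1 to compound 2 (beyond the scatter), a number 21 percentage points higher from compound 1 to compound 3 (beyond the scatter) and a number 9 percentage points lower from compound 2 to compound 3 (within the scatter). Leaving the bulky naphthalene group gave modest gains, while swapping one small aromatic group for another stayed within the scatter. A small aromatic ring again enters here, so no step beyond the scatter is expected. Compound 4 is therefore estimated at 25%, with a range from 5% to 45%. The expected step is a number 5 percentage points lower from compound 2 to compound 4 (within the scatter).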

Compound 4, a percentage reported as activity, at one concentration (the size of the read-out at that concentration, not a potency): 10%
Compound 4: middle estimate off by 15 percentage points, on the high side, and the stated range covers the measured number.
By their numbers in this assay, from the lowest: compounds 1 and 4 (each within the scatter of the next); then compounds 3 and 2 (each within the scatter of the next).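

Among these compounds, the one earlier exchange between small aromatic groups at this saturated ring carbon stayed within the scatter, but a small aromatic ring alone does not preserve the read-out in this assay. Here the 4-hydroxyphenyl group gives a number 20 percentage points lower from compound 2 to compound 4 (beyond the scatter) and also a number 11 percentage points lower from compound 3 to compound 4 (beyond the scatter). Against the naphthalene-bearing compound the result is a number 10 percentage points higher from compound 1 to compound 4 (within the scatter), so the modest gains seen with compound 2 and compound 3 do not extend to compound 4, and no measurement at hand explains this difference.

The change from 2-methoxyphenyl to 4-hydroxyphenyl alters both the oxygen substituent and its place on the ring, and the compounds shown cannot separate these two changes; 4-methoxyphenyl and 2-hydroxyphenyl would do so. On these data alone, how a 4-aminophenyl or 4-carboxyphenyl group would behave at this ring carbon also remains open.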